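Phenethyl thioether in the benzamide series, growth inhibition

The source may hold more compounds than are shown below. What is called first, only, known or untested is meant among the compounds shown, and "the series" means these compounds.

Compound 2 `Nc1ccccc1NC(=O)c1ccc(CSc2cccc(F)c2)cc1` gives 83% in a functional assay on SMMC-7721 cells (Homo sapiens) for inhibition, read by CCK-8 assay, with a stated time of 72 h, tested at 8 uM (on this read-out lower numbers stand for less inhibition of growth and higher numbers for more inhibition of growth at the one concentration tested), the highest of the three numbers measured, though compound 1 `Nc1ccccc1NC(=O)c1ccc(CSc2nccc(C(F)(F)F)n2)cc1` with 80.6% lies within the scatter of it, and only compound 3 `Nc1ccccc1NC(=O)/C=C/c1ccc(CSCCc2ccccc2)cc1` with 15.8% stands beyond the scatter below it. Compound 4 `Nc1ccccc1NC(=O)c1ccc(CSCCc2ccccc2)cc1` is not yet measured; it differs from compound 2 by phenethyl in place of 3-fluorophenyl on a sulfur. Among the compounds with values here, no measured pair shows this change on its own. Compound 3 also carries a phenethyl on sulfur but differs elsewhere in its structure, so its value only hints that a drop may follow. For compound 4 a step of a number 38 percentage points lower from compound 2 to compound 4 (beyond the scatter) is expected, downward and beyond the scatter. Compound 4 is estimated at 45%, within 15% to 78%.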

Compound 4, percent growth inhibition at one concentration: 77.9%
Compound 4: middle estimate off by 32.9 percentage points, on the low side; low and high end bracket the measured number.
By their numbers in this assay, from the lowest: compound 3; then compounds 4, 1 and 2 (each within the scatter of the next).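

Phenethyl in place of 3-fluorophenyl on a sulfur, seen here on its own for the first time, gives a number 5.1 percentage points lower from compound 2 to compound 4 (within the scatter) in this assay at this position. The phenethyl alone therefore does not go with the low number of compound 3 at 15.8% in this series. No evidence on hand bears on this result.

Open, going by these compounds, is whether a longer chain on the sulfur, or one ending in an amine or a carboxylic acid, keeps this level of growth inhibition. Also open, on these data alone, is whether the same holds at other concentrations.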